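A few compounds are considered here, and "the series" means these few. Any claim that something is new, unique, unknown or untested is made for them only; others in the source may bear on it.

Compound 1 `CCCCCCCN1CCC(C(=O)Nc2cc(Cl)c(N)cc2OC)CC1` gives in a functional assay on the whole organism for antagonist activity, with Mus musculus as the target (on this read-out lower numbers stand for an effect already at smaller amounts and higher numbers for an effect only at larger amounts of compound), a value of > 10 mg/kg, which is a limit of the assay.
Compound 2 `CCOc1ccc(CN2CCC(C(=O)Nc3cc(Cl)c(N)cc3OC)CC2)cc1` gives in this assay a value of 6.3 mg/kg.
Compound 3 `CCN1CCC(C(=O)Nc2cc(Cl)c(N)cc2OC)CC1` gives in this assay a value of > 10 mg/kg, again a limit of the assay.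

Compound 3 thus stands at the limit of > 10 mg/kg in this assay, at which 2 of the 3 values shown sit, so only a bound and no number is known for it. Compound 4 `COc1cc(N)c(Cl)cc1NC(=O)C1CCN(Cc2cccc(Cl)c2)CC1` differs from compound 3 in one place: 3-chlorophenyl in place of methyl on a saturated chain carbon bound to an amine nitrogen in a ring. Going by the values given here, two measured steps bear on this change. Going from compound 2 to compound 3, methyl in place of 4-ethoxyphenyl gave an at least 1.5-fold higher number from compound 2 to compound 3 (0.20 log units; that floor lies within the scatter); going from compound 1 to compound 2, 4-ethoxyphenyl in place of hexyl gave an at least 1.5-fold lower number from compound 1 to compound 2 (0.20 log units; that floor lies within the scatter). Among the compounds with values here, in both cases the compound carrying the phenyl group was the one returning a number rather than a limit. Compound 4 carries 3-chlorophenyl at the same position, so a lower number than the bound of compound 3 is expected, its size uncertain. Compound 4 is therefore expected to give about 5 mg/kg in this assay, between 2 mg/kg and 15 mg/kg. This amounts to an expected step of an at least 2.0-fold lower number from compound 3 to compound 4 (0.30 log units; that floor lies within the scatter).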

Compound 4, dose for half-maximal effect: > 4 mg/kg
Compound 4 ended at the assay's limit; the forecaster's own chance of this, stated with the estimate: 30%; the middle value lies beyond the limit too.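

In this assay compound 4 gives > 4 mg/kg, which is a limit of the assay and not a number, so its steps from compound 1, compound 2 and compound 3 cannot be read. The compounds shown leave open how compound 4 stands against compound 2 and whether 3-chlorophenyl in place of methyl changes the read-out at all.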